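Diethylamino for Dimethylamino: Notes Toward Compound 4

The source may hold more compounds than are shown below. What is called first, only, known or untested is meant among the compounds shown, and "the series" means these compounds.

compound 1 `CN(C)CCCCn1c(N)c(-c2nc3ccccc3o2)c2nc(C#N)c(C#N)nc21` — 1950 nM in a functional assay on HeLa cells (Homo sapiens) for antiproliferative activity, read by MTT assay, with a stated time of 48 h; a higher number here means a weaker inhibitor, a lower number a stronger inhibitor
compound 2 `CCN(CC)CCCCn1c(N)c(-c2nc3ccccc3o2)c2nc(C#N)c(C#N)nc21` — 6420 nM
compound 3 `CN(C)CCn1c(N)c(-c2nc3cc(Cl)ccc3[nH]2)c2nc(C#N)c(C#N)nc21` — > 50000 nM

Compound 2 differs from compound 1 by diethylamino in place of dimethylamino on a saturated chain carbon, four bonds along the chain from an aromatic nitrogen. That change gives a 3.3-fold higher number from compound 1 to compound 2 (0.52 log units; beyond the scatter).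

Compound 3 carries a different core; the difference between the two cores is not broken down here. In this assay compound 3 reaches only a limit of the assay, > 50000 nM, not a number (the limit of > 50000 nM in this assay, at which 1 of the 3 values shown sits).

Compound 4 `CCN(CC)CCn1c(N)c(-c2nc3cc(Cl)ccc3[nH]2)c2nc(C#N)c(C#N)nc21` is not yet measured. It differs from compound 3 by diethylamino in place of dimethylamino on a saturated chain carbon, two bonds along the chain from an aromatic nitrogen, the same kind of change as before, but set two bonds along the chain from the aromatic nitrogen rather than four.

Because the earlier pair showed a 3.3-fold higher number from compound 1 to compound 2 (0.52 log units; beyond the scatter), compound 4 is expected to show a step that the limit leaves unreadable from compound 3 to compound 4 and to stay at the limit of this assay. The estimate for compound 4 in this assay is 120000 nM, expected between 50000 nM and 400000 nM.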

Compound 4, half-maximal inhibitory concentration: > 50000 nM
Compound 4: a limit, no number (the forecaster's own chance of this, stated with the estimate: 90%); the middle value lies beyond the limit too.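

In this assay, for the compounds shown here, compound 4 gives > 50000 nM, a limit and not a number; compound 3 also stands at a limit, so no step between them can be read. Still open, as far as these compounds go, is whether diethylamino in place of dimethylamino, two bonds along the chain from an aromatic nitrogen, shifts the number at all.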